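A few compounds are considered here, and "the series" means these few. Any claim that something is new, unique, unknown or untested is made for them only; others in the source may bear on it.

Measured compounds:
Compound 1, `O=C(CSc1nc(Nc2ccccc2)c2ccccc2n1)Nc1ccccc1Br` — 14100 nM
Compound 2, `O=C(CSc1nc(Nc2ccccc2)c2ccccc2n1)Nc1cccc(Cl)c1` — 16500 nM

Among the compounds with values here, in a functional assay on MDA-MB-231 cells (Homo sapiens) for inhibition, read by MTT assay, with a stated time of 72 h (a higher number here means a weaker inhibitor, a lower number a stronger inhibitor), compound 2 gives 16500 nM, the higher of the two numbers so far, though its distance from compound 1 at 14100 nM is only a 1.2-fold higher number from compound 1 to compound 2 (0.07 log units; within the scatter), a gap that lies within the scatter. Compound 3, `O=C(CSc1nc(Nc2ccccc2)c2ccccc2n1)Nc1ccc(F)c(Cl)c1`, is not yet measured. It differs from compound 2 by fluoro in place of hydrogen on an aromatic carbon. Within the data shown here, no measured step adds a fluoro group, so only the single step from compound 1 to compound 2, which swapped one halogenated phenyl for another on the amide-type nitrogen and moved the number by a 1.2-fold higher number from compound 1 to compound 2 (0.07 log units; within the scatter), bears on this change, and it suggests that halogen changes on this ring leave the number roughly where it was. Compound 3 is therefore expected to show a step of a 1.1-fold lower number from compound 2 to compound 3 (0.04 log units; within the scatter), which is no change beyond the scatter. The estimate for compound 3 in this assay is 15000 nM, within a range from 6000 nM to 40000 nM.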

Compound 3, half-maximal inhibitory concentration: 21600 nM
For compound 3 the middle estimate is 1.4-fold (0.16 log units) below the measured one, and the stated range covers the measured number.
By their numbers in this assay, from the lowest: compounds 1, 2 and 3 (each within the scatter of the next).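

In this assay, placing fluoro on this aromatic carbon, ortho to a chloro group and para to a large group, gives a 1.3-fold higher number from compound 2 to compound 3 (0.12 log units; within the scatter) and so brings no change that can be told from the scatter. Exchanging 2-bromophenyl for 3-chloro-4-fluorophenyl on the amide-type nitrogen gives a 1.5-fold higher number from compound 1 to compound 3 (0.19 log units; within the scatter), so even with a second halogen on the ring, the three compounds all stay within the scatter of one another. No evidence is available to explain this result.

What an amine or a carboxylic acid at this position would do remains open, since every ring substituent shown is a halogen. Also open, on these data alone, is whether a longer chain between the sulfur and the carbonyl would move the number beyond the scatter.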